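Fluoro in place of hydrogen on the iodo compound

This account rests on a few compounds, and the source may have more. Where it says the series, first, only, none or still open, it means among the compounds named here.

Measured in a functional assay on cells (Homo sapiens) for antiproliferative activity, read by WST assay, with a stated time of 3 days; a lower number here means a stronger inhibitor, a higher number a weaker inhibitor:
- compound 1 `O=c1cc(I)n([C@@H]2O[C@H](CO)[C@@H](O)[C@H]2O)c(=O)[nH]1`: 27800 nM
- compound 2 `O=c1cc(NO)n([C@@H]2O[C@H](CO)[C@@H](O)[C@H]2O)c(=O)[nH]1`: > 50000 nM (a limit of the assay)

Among the compounds with values here, compound 1 holds the only actual number in this small series, so there is no spread of values against which to rank it. Compound 2 gives only a limit of the assay, > 50000 nM.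

The next compound to be read is compound 3 `O=c1[nH]c(=O)n([C@@H]2O[C@H](CO)[C@@H](O)[C@H]2O)c(I)c1F`. It keeps the iodo group of compound 1 and carries fluoro in place of hydrogen on an aromatic carbon, ortho to the iodo group: fluoro in place of hydrogen on an aromatic carbon.

One measured step exists, an at least 1.7-fold higher number from compound 1 to compound 2 (0.25 log units; that floor lies within the scatter). It replaces the iodo group and leaves the hydrogen untouched, so it bears only indirectly on this change and gives no size for it. Within the data shown here, with no measured precedent for fluoro, no step beyond the scatter is expected in this assay, in either direction, though the uncertainty is wide. The expected change is a 1.5-fold lower number from compound 1 to compound 3 (0.19 log units; within the scatter).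

For compound 3 the estimated value is 18000 nM, with an expected range of 4000 nM to 50000 nM.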

Compound 3, half-maximal inhibitory concentration: > 50000 nM
Compound 3 ended at the assay's limit; the forecaster's own chance of this, stated with the estimate: 15%; middle value at least 2.7-fold (0.44 log units) from the limit.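

In this assay compound 3 gives > 50000 nM, which is a limit of the assay and not a number. Fluoro in place of hydrogen, ortho to the iodo group, thus brings no measurable gain in potency on compound 1, and the change reads only as a floor: an at least 1.7-fold higher number from compound 1 to compound 3 (0.25 log units; that floor lies within the scatter). The carbon that carries hydrogen in compound 1 now has a result of its own, and both single changes shown on compound 1, this one and hydroxyamino in place of iodo, end at the same limit, with no compound shown going against that: the limit of > 50000 nM in this assay, at which 2 of the 3 values shown sit.

As far as these compounds go, how far compound 3 really lies from compound 1 stays open, so a real loss on adding fluoro cannot be told from a difference within the scatter. Also open, from the compounds shown here alone, is whether another group on this carbon, such as chloro, methyl or an amine, would give a measurable number, and how that number would compare with compound 1 at 27800 nM.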